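This account rests on a few compounds, and the source may have more. Where it says the series, first, only, none or still open, it means among the compounds named here.

In an assay for inhibition of Fatty-acid amide hydrolase 1 (Rattus norvegicus) (on this read-out higher numbers stand for weaker inhibition and lower numbers for stronger inhibition), compound 1 `NC(=O)c1ccc(-c2cnc(C(O)CCc3ccc(-c4ccccc4)cc3)o2)nc1` gives only a limit, > 1000 nM, and stands at the limit of > 1000 nM in this assay, at which 1 of the 2 values shown sits. For the measured compounds named here, compound 2 `O=C(CCc1ccc(-c2ccccc2)cc1)c1ncc(-c2ccncc2)o1` in this assay gives 2.3 nM; no single-point step links it to compound 1, so its value is noted only for comparison. Compound 3 `COC(=O)c1ccc(-c2cnc(C(O)CCc3ccc(-c4ccccc4)cc3)o2)nc1` differs from compound 1 by methoxy in place of amino on a carbonyl carbon. Going by the values given here, with compound 1 at the limit, no measured step tells the size or direction of this change, and no shift beyond the scatter is expected; the estimated step from compound 1 to compound 3 is a step that the limit leaves unreadable from compound 1 to compound 3. Compound 3 is expected to give about 3000 nM, between 600 nM and 20000 nM.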

Compound 3, inhibition constant: 1100 nM
Compound 3: middle estimate off by 2.7-fold (0.44 log units), on the high side; the measured number falls inside the stated range.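

Compound 1 and compound 3 yield no readable new step, because compound 1 stands only at a limit: the limit of > 1000 nM in this assay, at which 1 of the 3 values shown sits.

The compounds shown leave open whether methoxy in place of amino on a carbonyl carbon changes inhibition at all, and in which direction.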